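A few compounds are considered here, and "the series" means these few. Any claim that something is new, unique, unknown or untested is made for them only; others in the source may bear on it.

Compound 1 `C=CC1=C(C(=O)Nc2ccccc2)C(c2ccc(Cl)c(Cl)c2)OC1`: in a functional assay on QGY7701 cells (Homo sapiens) for cytotoxicity, read by MTT assay, with a stated time of 24 h (a higher number here means a weaker inhibitor, a lower number a stronger inhibitor), compound 1 gives > 100000 nM, which is a limit of the assay and not a number.
Compound 2 `C=CC1=C(C(=O)NC2CCCCC2)C(c2ccc(OC)c(OC)c2)OC1`: in this assay compound 2 gives 7490 nM.
Compound 3 `C=CC1=C(C(=O)NC2CCCCC2)C(c2ccc(OC)cc2)OC1`: in this assay compound 3 gives > 100000 nM, again a limit of the assay.

Within the data shown here, compound 2 therefore holds the only number measured; the other two compounds sit at the limit of > 100000 nM in this assay, at which 2 of the 3 values shown sit. Among the measured compounds shown here, the one step between measured compounds is an at least 13-fold higher number from compound 2 to compound 3 (1.12 log units; beyond the scatter), and it concerns the methoxy groups on the aromatic ring, which compound 4 `C=CC1=C(C(=O)NCc2ccc(Cl)cc2)C(c2ccc(OC)c(OC)c2)OC1` keeps intact.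

Compound 4 differs from compound 2 by 4-chlorobenzyl in place of cyclohexyl on an amide-type nitrogen. For the measured compounds named here, no measured step touches the amide substituent, so the measured evidence gives no direction for this change; the three compounds differ among themselves only at the aromatic ring. The author therefore expects no step beyond the scatter, a 1.0-fold higher number from compound 2 to compound 4 (0.00 log units; within the scatter), and estimates for compound 4 a value of 7500 nM, between 2000 nM and 30000 nM.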

Compound 4, half-maximal inhibitory concentration: > 100000 nM
Compound 4 gave a limit, no number; the forecaster's own chance of this, stated with the estimate: 15%; middle value at least 13-fold (1.12 log units) away from the limit.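

Among these compounds, the amide substituent, which no earlier step had touched, proves to matter in this assay: 4-chlorobenzyl in place of cyclohexyl on the amide-type nitrogen gives an at least 13-fold higher number from compound 2 to compound 4 (1.12 log units; beyond the scatter). A single change at this nitrogen thus costs compound 2 its measurable value, just as a single change on the aromatic ring does with an at least 13-fold higher number from compound 2 to compound 3 (1.12 log units; beyond the scatter). Compound 4 gives > 100000 nM, a limit of the assay and not a number: the limit of > 100000 nM in this assay, at which 3 of the 4 values shown sit.

The compounds shown leave open whether the step follows from the chlorine, from the benzyl group as a whole, or from the removal of cyclohexyl. Plain benzyl, cyclopentyl or a straight hexyl chain on this nitrogen, each carried on the core of compound 2, would tell these apart.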